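Swapping the Ether Side Chain and Liver-Cell Tolerance

A few compounds are considered here, and "the series" means these few. Any claim that something is new, unique, unknown or untested is made for them only; others in the source may bear on it.

Of the compounds shown here, three sharing one core have been tested in an ADME assay on Huh-7 cells (Homo sapiens) for cytotoxicity, with a stated time of 72 h; a lower number here means that less compound is tolerated, a higher number that more compound is tolerated. Compound 1 `CC(C)CCn1nc(-c2cccs2)c(O)c(C2=NS(=O)(=O)c3cc(O)ccc3N2)c1=O` carries a free hydroxyl on its aromatic ring; in this assay compound 1 gives > 25000 nM, which is a limit of the assay rather than a number. Compound 2 `CC(C)CCn1nc(-c2cccs2)c(O)c(C2=NS(=O)(=O)c3cc(OCC(N)=O)ccc3N2)c1=O` gives 78000 nM in this assay. Compound 3 `CCC(Oc1ccc2c(c1)S(=O)(=O)N=C(c1c(O)c(-c3cccs3)nn(CCC(C)C)c1=O)N2)C(N)=O` gives > 33000 nM in this assay, which is again only a limit. Compound 3 therefore stands without a firm number, and of the two other values shown, one is also a limit. The step that the two limits leave unreadable from compound 1 to compound 3 and the step that the limit leaves unreadable from compound 2 to compound 3 are both unreadable in size, and the step that the limit leaves unreadable from compound 1 to compound 2 is unreadable too. Compound 4 `CC(C)CCn1nc(-c2cccs2)c(O)c(C2=NS(=O)(=O)c3cc(OCC(=O)NO)ccc3N2)c1=O` differs from compound 3 by (hydroxycarbamoyl)methyl in place of 1-carbamoylpropyl on an oxygen on an aromatic ring. For the measured compounds named here, no measured step bearing on this change gives a readable size, so nothing points to a shift beyond the usual scatter. The expected step is accordingly a step that the limit leaves unreadable from compound 3 to compound 4, none beyond the scatter. Compound 4 is expected to give 40000 nM in this assay, with a range from 15000 nM to 100000 nM.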

Compound 4, half-maximal cytotoxic concentration: > 33000 nM
Compound 4: no number, only a limit (the forecaster's own chance of this, stated with the estimate: 60%); the middle value does not contradict the limit.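

Compound 4 gives only a limit of the assay, so its steps from compound 1, compound 2 and compound 3 cannot be read. With compound 2 alone holding a firm number, the compounds shown leave open whether changing the ether side chain shifts tolerance in this assay at all.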